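Thiophen-3-yl in place of thiophen-2-yl: working notes

This account rests on a few compounds, and the source may have more. Where it says the series, first, only, none or still open, it means among the compounds named here.

Measured so far:
Compound 1 `COc1ncnc2c1c(-c1ccsc1)cn2[C@@H]1O[C@H](CO)[C@@H](O)[C@H]1O` gives 3450 nM in a functional assay on K562 cells (Homo sapiens), read by MTT assay, with a stated time of 72 h; a lower number here means a stronger inhibitor, a higher number a weaker inhibitor.
Compound 2 `COc1ncnc2c1c(-c1cccs1)cn2[C@@H]1O[C@H](CO)[C@@H](O)[C@H]1O` gives 6200 nM in this assay.
Compound 3 `CNc1ncnc2c1c(-c1cccs1)cn2[C@@H]1O[C@H](CO)[C@@H](O)[C@H]1O` gives only a limit of the assay, > 20000 nM, in this assay.

Two changes cover the set. The first, (thiophen-3-yl in place of thiophen-2-yl on an aromatic carbon), gives a 1.8-fold lower number from compound 2 to compound 1 (0.25 log units; within the scatter). The second, (methylamino in place of methoxy on an aromatic carbon), gives an at least 3.2-fold higher number from compound 2 to compound 3 (0.50 log units; beyond the scatter); compound 3 sits at the limit of > 20000 nM in this assay, at which 1 of the 3 values shown sits, so only a limit is known for it.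

Compound 4 `CNc1ncnc2c1c(-c1ccsc1)cn2[C@@H]1O[C@H](CO)[C@@H](O)[C@H]1O` is not yet measured. It differs from compound 3 by thiophen-3-yl in place of thiophen-2-yl on an aromatic carbon, the same kind of change as from compound 2 to compound 1, at the same place in both cases. That earlier step is within the scatter, so little movement is expected from the thiophene change here either. Compound 4 is therefore expected to stay near the limit of compound 3, with an estimated step of a number no higher from compound 3 to compound 4 (the limit leaves the size open) in this assay. The estimate for compound 4 is 20000 nM, between 8000 nM and 50000 nM, and a limit rather than a number is quite possible.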

Compound 4, half-maximal inhibitory concentration: > 20000 nM
Compound 4: only a limit was reported; the forecaster's own chance of this, stated with the estimate: 60%; the middle value sits exactly at the limit.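

In this assay, methylamino in place of methoxy on an aromatic carbon gives an at least 5.7-fold higher number from compound 1 to compound 4 (0.76 log units; beyond the scatter), so the direction of the change seen on the thiophen-2-yl core carries over to the thiophen-3-yl core: the same change on two cores in this assay, an at least 3.2-fold higher number (0.50 log units; beyond the scatter) from compound 2 to compound 3 and an at least 5.7-fold higher number (0.76 log units; beyond the scatter) from compound 1 to compound 4; the limit leaves it open whether they differ

Compound 3 and compound 4 both stand at a limit of the assay, so the step between them, thiophen-3-yl in place of thiophen-2-yl, cannot be read. The true size of the methylamino change on either core stays unknown, and so does any difference between the two cores, since both steps end at a limit: the limit of > 20000 nM in this assay, at which 2 of the 4 values shown sit.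

Going by these compounds, whether an unsubstituted amine, a dimethylamino group or an ethoxy group on that aromatic carbon would give a readable number remains open. Also open, on these data alone, is whether the thiophene change has a readable effect with any group other than methoxy at that place.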